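A few compounds are considered here, and "the series" means these few. Any claim that something is new, unique, unknown or untested is made for them only; others in the source may bear on it.

Measured compounds in an assay on isolated protein for binding affinity to adenosine receptor A1 (Bos taurus); a higher number here means a weaker inhibitor, a lower number a stronger inhibitor:
Compound 1 `Fc1ccccc1Cn1nnc2c(NC3CC3)nc(-c3ccccc3)nc21`: compound 1 gives 15000000 nM
Compound 2 `OCCNc1nc(-c2ccccc2)nc2c1nnn2Cc1ccccc1F`: compound 2 gives 54000000 nM
Compound 3 `CCCCCCNc1nc(-c2ccccc2)nc2c1nnn2Cc1ccccc1F`: compound 3 gives 25000000 nM

Among these three numbers compound 3 stands second highest. Its nearest neighbour is compound 1, reached by a 1.7-fold higher number from compound 1 to compound 3 (0.22 log units; within the scatter), a step that stays within the scatter. Its furthest neighbour is compound 2, with a 2.2-fold lower number from compound 2 to compound 3 (0.33 log units; beyond the scatter), a modest step beyond the scatter.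

Compound 4 `CCNc1nc(-c2ccccc2)nc2c1nnn2Cc1ccccc1F` differs from compound 3 by hydrogen in place of butyl on a saturated chain carbon, two bonds along the chain from a nitrogen on an aromatic ring. For the measured compounds named here, two measured steps bear on this change. The step of a 2.2-fold lower number from compound 2 to compound 3 (0.33 log units; beyond the scatter) shows that building out the chain on the nitrogen gave a modestly lower number, so cutting the chain back might be expected to run the other way, though the group that enters here is hydrogen rather than hydroxy. The step of a 1.7-fold higher number from compound 1 to compound 3 (0.22 log units; within the scatter) shows that a small ring and a long chain on that nitrogen give numbers within the scatter of one another, and ethyl is closer in extent to cyclopropyl than to hexyl. Taken together, compound 4 is expected to give no change at the digits printed from compound 3 to compound 4 (within the scatter), at most a small rise and quite possibly nothing beyond the scatter.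

The estimate for compound 4 in this assay is therefore 25000000 nM, with a range from 10000000 nM to 65000000 nM.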

Compound 4, inhibition constant: 11000000 nM
Estimate against measurement, compound 4: 2.3-fold (0.36 log units) above, within the range that was stated.
By their numbers in this assay, from the lowest: compounds 4, 1 and 3 (each within the scatter of the next, the first and the last beyond it); then compound 2.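

In this assay, shortening hexyl to ethyl on the nitrogen on an aromatic ring gives a 2.3-fold lower number from compound 3 to compound 4 (0.36 log units; beyond the scatter), so a change in chain length alone can move the number beyond the scatter at this position, which the comparison of cyclopropyl with hexyl had not shown. With the chain length held at two carbons, the hydroxy of the 2-hydroxyethyl group also proves to matter, as replacing it with hydrogen gives a 4.9-fold lower number from compound 2 to compound 4 (0.69 log units; beyond the scatter), while a 1.4-fold lower number from compound 1 to compound 4 (0.13 log units; within the scatter) means that ethyl and cyclopropyl cannot be told apart here. For the compounds shown here, nothing measured so far accounts for these shifts.

The compounds shown leave open how the number runs through the chain lengths between ethyl and hexyl, such as butyl, and whether methyl or a bare amino group on the core would fall in line with ethyl. They also leave open whether an amine or a carboxylic acid at the end of the two-carbon chain would raise the number as hydroxy does in compound 2.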